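The compounds below may be only part of what the source reports. "The series", "measured", "known", "first", "only" and "open" are said of these compounds alone.

Measured in a functional assay for inhibition, with Homo sapiens as the target; on this read-out lower numbers stand for tighter binding and higher numbers for weaker binding:
- compound 1 `CC(C)(Oc1ccccc1)C1OCC(C/C=C\CCC(=O)O)C(c2cccnc2)O1`: 75.9 nM
- compound 2 `Cc1ccc(C#N)c(OC(C)(C)C2OCC(C/C=C\CCC(=O)O)C(c3cccnc3)O2)c1`: 15.9 nM
- compound 3 `CC(C)(Oc1ccc(F)cc1[N+](=O)[O-])C1OCC(C/C=C\CCC(=O)O)C(c2cccnc2)O1`: 2.51 nM

Compound 3 has the lowest of the three numbers. Compound 2 is its nearest neighbour, as shown by a 6.3-fold lower number from compound 2 to compound 3 (0.80 log units; beyond the scatter), and compound 1 is furthest, as shown by a 30-fold lower number from compound 1 to compound 3 (1.48 log units; beyond the scatter).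

Compound 4 `Cc1ccc(SC(C)(C)C2OCC(C/C=C\CCC(=O)O)C(c3cccnc3)O2)c([N+](=O)[O-])c1` is unmeasured. Its structural change from compound 3 is a group of 11 heavy atoms (7 carbon, 1 nitrogen, 2 oxygen, 1 sulfur; one six-membered aromatic ring of carbon only) in place of a group of 11 heavy atoms (6 carbon, 1 nitrogen, 3 oxygen, 1 fluorine; one six-membered aromatic ring of carbon only), on a saturated chain carbon bound to two saturated chain carbons and a saturated ring carbon.

All three measured steps bear on this change only indirectly. Each swaps the aromatic group on an oxygen on a saturated carbon, and they range from the modest 4.8-fold lower number from compound 1 to compound 2 (0.68 log units; beyond the scatter) to the large 30-fold lower number from compound 1 to compound 3 (1.48 log units; beyond the scatter). Among the compounds with values here, none of them involves a group containing sulfur, so no direct precedent exists.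

With compound 3 at 2.51 nM, the lowest so far, a modest move toward a higher number in this assay is expected rather than a further drop. The estimated step is a 2.4-fold higher number from compound 3 to compound 4 (0.38 log units; beyond the scatter). For compound 4 the expected value is 6 nM, with an estimated range of 1.5 nM to 25 nM.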

Compound 4, dissociation constant: 158 nM
The estimate for compound 4 lay 26-fold (1.42 log units) below the measured number; the measured number lies above the stated range.
By their numbers in this assay, from the lowest: compound 3; then compound 2; then compound 1; then compound 4.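

In this assay, the first group containing sulfur at this place, on a saturated chain carbon bound to two saturated chain carbons and a saturated ring carbon, gives a 63-fold higher number from compound 3 to compound 4 (1.80 log units; beyond the scatter) despite having the same heavy-atom count as the group it replaces. The loss also reaches past the other two compounds, with a 9.9-fold higher number from compound 2 to compound 4 (1.00 log units; beyond the scatter) and a 2.1-fold higher number from compound 1 to compound 4 (0.32 log units; beyond the scatter), so a substituted aromatic group here does not by itself give a lower number than phenyl on an oxygen, and compound 4 goes against the trend set by compound 2 and compound 3. No measurement in hand accounts for this reversal.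

The change swaps an oxygen for sulfur and a fluorine for a carbon in one step, so the share of each remains unresolved. Also open, on these data alone, is how a phenyl group on sulfur, or a sulfone or an amine in place of that oxygen, would read in this assay.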